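The source may hold more compounds than are shown below. What is called first, only, known or untested is meant among the compounds shown, and "the series" means these compounds.

Measured so far:
compound 1 `CCCCCCCCOc1ccc(NC(=O)Oc2ccccc2F)cc1` – 19 nM
compound 2 `CCCCCCCCOc1ccc(NC(=O)O/N=C/c2cccnc2)cc1` – 0.8 nM

Within the data shown here, in an assay on H4 cells for inhibition of Fatty-acid amide hydrolase 1 (Homo sapiens) (on this read-out lower numbers stand for stronger inhibition and higher numbers for weaker inhibition), compound 1 holds the higher of the two numbers; the only measured step, a 24-fold lower number from compound 1 to compound 2 (1.38 log units; beyond the scatter), concerns the exchange of one ring for another and not the chain. Compound 3 `CCCCCCCCCCOc1ccc(NC(=O)Oc2ccccc2F)cc1` differs from compound 1 by ethyl in place of hydrogen on a saturated chain carbon, eight bonds along the chain from an oxygen on an aromatic ring. Among the measured compounds shown here, no measured step bears on this chain lengthening, so the series gives no guide, and a change of about the usual scatter is expected, with a slight lean toward a lower number. For compound 3 the expected step is a 1.3-fold lower number from compound 1 to compound 3 (0.10 log units; within the scatter). Compound 3 is estimated at 15 nM, range 5 nM to 50 nM.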

Compound 3, half-maximal inhibitory concentration: 9.2 nM
Beside the measured number, compound 3's estimate is 1.6-fold (0.21 log units) above it; the measured number falls inside the stated range.
By their numbers in this assay, from the lowest: compound 2; then compound 3; then compound 1.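

In this assay, the saturated chain proves to be a position that can move the number: ethyl in place of hydrogen gives a 2.1-fold lower number from compound 1 to compound 3 (0.31 log units; beyond the scatter). This modest step is smaller than the ring exchange, a 24-fold lower number from compound 1 to compound 2 (1.38 log units; beyond the scatter), but it shows that the ring is not the only part that matters. No available evidence bears on the reason for the shift.

On these data alone, whether a longer chain, such as dodecyl, lowers the number further remains open. So does whether a terminal carboxylic acid on the chain is tolerated, or whether the same lengthening carries over to compound 2.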